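Swapping ethynyl for a larger aromatic group

The compounds below may be only part of what the source reports. "The series", "measured", "known", "first", "only" and "open" are said of these compounds alone.

Compound 1 `COc1ccc(NC(=O)CCc2cccc3c2B(O)OC3)cc1`: 900 nM
Compound 2 `C#Cc1cccc(NC(=O)CCc2cccc3c2B(O)OC3)c1`: 980 nM

In a functional assay on SK-OV-3 cells (Homo sapiens) for antiproliferative activity, read by MTT assay, with a stated time of 72 h (a higher number here means a weaker inhibitor, a lower number a stronger inhibitor), compound 2 gives 980 nM, which lies within the usual scatter of compound 1 at 900 nM. Among the measured compounds shown here, these two compounds therefore stand level, and no measured step between compounds that differ in one place is available as a guide.

Compound 3 `COc1cc(OC)cc(-c2cccc(NC(=O)CCc3cccc4c3B(O)OC4)c2)c1` carries 3,5-dimethoxyphenyl in place of ethynyl on an aromatic carbon. This is a sizeable change, so the expectation in this assay is a tentative one, leaning towards a stronger inhibitor.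

The expected size of this move is a 4.9-fold lower number from compound 2 to compound 3 (0.69 log units; beyond the scatter).

For compound 3, the estimated value is 200 nM, within an expected range of 30 nM to 1200 nM.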

Compound 3, half-maximal inhibitory concentration: 44 nM
The estimate for compound 3 lay 4.5-fold (0.66 log units) above the measured number, and the stated range covers the measured number.
By their numbers in this assay, from the lowest: compound 3; then compounds 1 and 2 (each within the scatter of the next).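

In this assay, putting 3,5-dimethoxyphenyl on this aromatic carbon in place of ethynyl gives a 22-fold lower number from compound 2 to compound 3 (1.35 log units; beyond the scatter). Among the compounds shown here, this is the first measured sign that this position responds strongly to what it carries, and that a much larger group bearing an aromatic ring is accepted here. No measurement shown explains the drop.

On these data alone, it remains open whether the aromatic ring alone accounts for the step or the two methoxy groups also contribute. An unsubstituted phenyl group would help separate the two.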